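Phenyl-ring substitution from compound 3 to compound 4

The source may report more compounds than this note shows. Statements on the series, on what has been measured and on what is new or still open speak of the compounds shown alone.

Of the compounds shown here, three have been measured in a functional assay on NCI-H460 cells (Homo sapiens) for cytotoxicity, read by MTT assay, with a stated time of 72 h; on this read-out higher numbers stand for weaker inhibition and lower numbers for stronger inhibition. Compound 1 `COc1cc2c(Oc3ccc(NC(=O)c4cc(-c5ccccc5)ccn4)cc3F)ccnc2cc1OCCCN1CCN(C)CC1` gives 91 nM, compound 2 `COc1cc2c(Oc3ccc(NC(=O)c4cc(-c5ccccc5F)ccn4)cc3F)ccnc2cc1OCCCN1CCCCC1` gives 130 nM, and compound 3 `COc1cc2c(Oc3ccc(NC(=O)c4cc(-c5ccccc5F)ccn4)cc3F)ccnc2cc1OCCCN1CCN(C)CC1` gives 140 nM. Compound 3 carries the highest of the three numbers, but its separation from the others stays inside the scatter: the step of a 1.5-fold higher number from compound 1 to compound 3 (0.19 log units; within the scatter) and the step of a 1.1-fold higher number from compound 2 to compound 3 (0.03 log units; within the scatter) both fall within the usual spread, so the three cannot be ordered.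

Compound 4 `COc1ccc(-c2ccnc(C(=O)Nc3ccc(Oc4ccnc5cc(OCCCN6CCN(C)CC6)c(OC)cc45)c(F)c3)c2)c(OC)c1` differs from compound 3 in one place: 2,4-dimethoxyphenyl in place of 2-fluorophenyl on an aromatic carbon. Within the data shown here, the only measured step touching this aromatic ring is a 1.5-fold higher number from compound 1 to compound 3 (0.19 log units; within the scatter), and it was within the scatter. The step of a 1.1-fold higher number from compound 2 to compound 3 (0.03 log units; within the scatter) sits elsewhere in the molecule and does not bear on the ring in question. Among the measured compounds shown here, no measured compound carries a methoxy group on this ring, and none carries two substituents on it at once, so the present change is larger than anything the measured steps cover. The expectation is therefore a number close to that of compound 3, with no direction favoured beyond the scatter, and a wider range to reflect the untested change. Compound 4 is estimated at 150 nM, with a range from 60 nM to 400 nM, which means an expected step of a 1.1-fold higher number from compound 3 to compound 4 (0.03 log units; within the scatter).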

Compound 4, half-maximal inhibitory concentration: 430 nM
Beside the measured number, compound 4's estimate is 2.9-fold (0.46 log units) below it; the measured number lies above the stated range.
By their numbers in this assay, from the lowest: compounds 1, 2 and 3 (each within the scatter of the next); then compound 4.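

In this assay, the aryl group on the carbon opposite the ring nitrogen now shows that it is not indifferent to substitution: the 2,4-dimethoxyphenyl group gives a 3.1-fold higher number from compound 3 to compound 4 (0.49 log units; beyond the scatter) and, measured against plain phenyl, a 4.7-fold higher number from compound 1 to compound 4 (0.67 log units; beyond the scatter), both modest but beyond the scatter. Among these compounds, the only earlier change on this ring, a 1.5-fold higher number from compound 1 to compound 3 (0.19 log units; within the scatter), stayed within the scatter, so a single fluoro group left no readable mark, while the larger change with two methoxy groups does, in the direction of weaker inhibition. Nothing available bears on the reason for this rise.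

Compound 4 introduces both methoxy groups at once and also removes the fluoro group, so the compounds shown do not separate the contribution of either methoxy group, and a phenyl carrying a single methoxy group would be needed to divide the step. Also open, going by these compounds, are how this ring responds to an amine or a carboxylic acid in place of methoxy, and whether the dimethoxy step holds with the piperidin-1-yl chain end of compound 2.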